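Cytotoxicity notes on compounds 1 to 3

The source may report more compounds than this note shows. Statements on the series, on what has been measured and on what is new or still open speak of the compounds shown alone.

Measured so far:
compound 1, `COc1cccc(OC)c1C(=O)Nc1c[nH]nc1C(=O)N[C@H]1CC[C@H](OC)CC1`, 31000 nM
compound 2, `COc1cccc(OC)c1C(=O)Nc1c[nH]nc1C(=O)NC1CCN(C(=O)OC(C)(C)C)CC1`, > 50000 nM (a limit of the assay)

Among the compounds with values here, in an ADME assay on MRC5 cells (Homo sapiens) for inhibition, with a stated time of 72 h (on this read-out higher numbers stand for an effect only at larger amounts of compound and lower numbers for an effect already at smaller amounts), compound 1 gives 31000 nM, the only plain number in the set. For compound 2 the assay reports only a limit, > 50000 nM. That result is the limit of > 50000 nM in this assay, at which 1 of the 2 values shown sits. Within the data shown here, no pair of measured compounds differs in one place, so no measured step is available, and the two values show only that compound 1 sits at a number while compound 2 sits at a limit.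

Compound 3, `COc1cccc(OC)c1C(=O)Nc1c[nH]nc1C(=O)NCCN1CCCC1`, is not yet measured. It differs from compound 1 by 2-(pyrrolidin-1-yl)ethyl in place of 4-methoxycyclohexyl on an amide-type nitrogen.

Among the measured compounds shown here, with no measured step to lean on, the expectation is that the change from compound 1 to compound 3 leaves this assay where compound 1 stands, within the usual scatter: the step of a 1.1-fold lower number from compound 1 to compound 3 (0.04 log units; within the scatter) is an estimate, not a measurement. Compound 3 is therefore expected to give 28000 nM, with the likely range from 9000 nM to 60000 nM, and a real chance that only a limit is reported.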

Compound 3, half-maximal effective concentration: > 50000 nM
Compound 3 gave a limit, no number; the forecaster's own chance of this, stated with the estimate: 35%; middle value at least 1.7-fold (0.25 log units) away from the limit.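

In this assay, within the data shown here, 2-(pyrrolidin-1-yl)ethyl in place of 4-methoxycyclohexyl on an amide-type nitrogen gives the first measured step: an at least 1.6-fold higher number from compound 1 to compound 3 (0.20 log units; that floor lies within the scatter). For compound 3 the value > 50000 nM is a limit of the assay, not a number, so the step gives only a floor, and that floor does not separate compound 3 from compound 1 beyond the scatter. What is new is that this position accepts a group carrying a ring nitrogen without any lower number appearing, and compound 1 is now the only compound with a plain number: the limit of > 50000 nM in this assay, at which 2 of the 3 values shown sit.

As far as these compounds go, the size of the change from 4-methoxycyclohexyl to 2-(pyrrolidin-1-yl)ethyl stays open, as the data do not show how far compound 3 lies from compound 1 in this assay. Also open, from the compounds shown here alone, is whether a morpholine on a longer chain, a primary amine or a carboxylic acid at this amide-type nitrogen would give a plain number in this assay or another limit.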